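Swapping the aryl group on the shared core

The compounds below may be only part of what the source reports. "The series", "measured", "known", "first", "only" and "open" are said of these compounds alone.

Measured compounds:
compound 1, `O=C(CN1CCCC1)Nc1ccc2ncnc(Nc3cccc(C(F)(F)F)c3)c2c1`: 25200 nM
compound 2, `CN1CCN(CC(=O)Nc2ccc3ncnc(Nc4cccc(C(F)(F)F)c4)c3c2)CC1`: > 100000 nM, which is a limit of the assay and not a number

Within the data shown here, in a functional assay on HepG2 cells (Homo sapiens) for antiproliferative activity, read by MTT assay, with a stated time of 48 h (on this read-out lower numbers stand for stronger inhibition and higher numbers for weaker inhibition), compound 1 gives 25200 nM, the only number among the two values shown. Compound 2 sits at the limit of the assay, (the limit of > 100000 nM in this assay, at which 1 of the 2 values shown sits). Among the measured compounds shown here, the one measured step, an at least 3.9-fold higher number from compound 1 to compound 2 (0.59 log units; beyond the scatter), concerns the amine on the saturated chain carbon bound to the carbonyl carbon, not the aryl group on the ring nitrogen. Compound 3, `O=C(CN1CCCC1)Nc1ccc2ncnc(Nc3ccc(Cl)cc3)c2c1`, differs from compound 1 in that aryl group: 4-chlorophenyl in place of 3-(trifluoromethyl)phenyl on a nitrogen on an aromatic ring. For the measured compounds named here, no measured step bears on this change, so the direction cannot be read from the data, and the expectation stays close to compound 1 with a wide range. For compound 3 the step of a 1.3-fold lower number from compound 1 to compound 3 (0.10 log units; within the scatter) is expected, giving an estimate of 20000 nM, between 5000 nM and 80000 nM.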

Compound 3, half-maximal inhibitory concentration: 18000 nM
Beside the measured number, compound 3's estimate is 1.1-fold (0.05 log units) above it; the range from low to high includes it.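

In this assay, among these compounds, the first measured step at the aryl group on the ring nitrogen leaves compound 1 and compound 3 indistinguishable (a 1.4-fold lower number from compound 1 to compound 3 (0.15 log units; within the scatter)), whereas the earlier step concerned only the amine on the chain. Here a 3-(trifluoromethyl)phenyl group of 10 heavy atoms gives way to a 4-chlorophenyl group of 7 heavy atoms, and the read-out does not separate the two. Among the compounds shown here, the only further information at hand concerns the assay limit reached by compound 2 and offers no explanation for this result.

From the compounds shown here alone, it remains open whether an unsubstituted phenyl, a 3-chlorophenyl or a 4-methoxyphenyl group would also stay within the scatter of compound 1. Going by these compounds, it is also open how 4-chlorophenyl would read with the 4-methylpiperazin-1-yl chain of compound 2, whose own reading is only a limit.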